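The source may hold more compounds than are shown below. What is called first, only, known or untested is meant among the compounds shown, and "the series" means these compounds.

Measured in a functional assay on the whole organism (strain Swiss CD-1) with Mus musculus as the target, with a stated time of 2 h; a lower number here means that less compound is needed, a higher number that more compound is needed for the effect:
- compound 1 `COCC(C(=O)N1CCN(c2cccc(Cl)c2)CC1)N1C(=O)CCC1=O`: 26.1 mg/kg
- compound 2 `COCC(C(=O)N1CCN(c2ccc(F)cc2)CC1)N1C(=O)CCC1=O`: 71.4 mg/kg
- compound 3 `COCC(C(=O)N1CCN(c2cccc(OC)c2)CC1)N1C(=O)CCC1=O`: > 100 mg/kg (a limit of the assay)

Compound 3 stands at > 100 mg/kg, which is a limit of the assay and not a number. Compound 4 `COCC(C(=O)N1CCN(C)CC1)N1C(=O)CCC1=O` carries methyl in place of 3-methoxyphenyl on an amine nitrogen in a ring.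

For the measured compounds named here, three measured steps bear on this change, but only indirectly, since all of them keep a phenyl group at that place. Modest in size is a 2.7-fold higher number from compound 1 to compound 2 (0.44 log units; beyond the scatter), and at least modest is an at least 3.8-fold higher number from compound 1 to compound 3 (0.58 log units; beyond the scatter). The floor of an at least 1.4-fold higher number from compound 2 to compound 3 (0.14 log units; that floor lies within the scatter) lies within the scatter. None of them shows what losing the phenyl group does, so the size of the next step stays uncertain.

In this assay no gain is expected: the number for compound 4 should stay near the limit of compound 3 or go higher, and another limit is likely. The estimated step is a step that the limit leaves unreadable from compound 3 to compound 4. For compound 4 the estimate is 130 mg/kg, with an expected range of 60 mg/kg to 300 mg/kg.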

Compound 4, dose for half-maximal effect: 68.2 mg/kg
For compound 4 the middle estimate is 1.9-fold (0.28 log units) above the measured one; the measured number falls inside the stated range.
By their numbers in this assay, from the lowest: compound 1; then compounds 4 and 2 (each within the scatter of the next). At a limit, above all of these: compound 3.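

In this assay, an aromatic ring on the amine nitrogen is not needed to reach the level of compound 2, since methyl in place of 4-fluorophenyl gives a 1.0-fold lower number from compound 2 to compound 4 (0.02 log units; within the scatter). The 3-chlorophenyl group is the only one shown that reads as separate from methyl, with a 2.6-fold higher number from compound 1 to compound 4 (0.42 log units; beyond the scatter). Methyl in place of 3-methoxyphenyl gives an at least 1.4-fold lower number from compound 3 to compound 4 (0.16 log units; that floor lies within the scatter), a floor within the scatter, and compound 3 stands at a limit of the assay: the limit of > 100 mg/kg in this assay, at which 1 of the 4 values shown sits.

Still open, going by these compounds, is how a benzyl group or a longer chain on this nitrogen would compare with methyl and with 3-chlorophenyl. Also open, on these data alone, is whether a 4-chlorophenyl or 3-fluorophenyl group would read like compound 1 or like compound 4, which would show whether the chloro group or its place on the ring sets compound 1 apart.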